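A few compounds are considered here, and "the series" means these few. Any claim that something is new, unique, unknown or untested is made for them only; others in the source may bear on it.

Compound 1, `COc1cc(C(=O)NS(=O)(=O)c2ccccc2C)ccc1Cc1cn(C(=O)N(C)C)c2ccc(NC(=O)OC3CCCC3)cc12`: in an assay on isolated protein for binding affinity to cysteinyl leukotriene receptor 1 (Cavia porcellus) (a higher number here means a weaker inhibitor, a lower number a stronger inhibitor), compound 1 gives 0.4 nM.
Compound 2, `CCN(CC)C(=O)n1cc(Cc2ccc(C(=O)NS(=O)(=O)c3ccccc3C)cc2OC)c2cc(NC(=O)OC3CCCC3)ccc21`: in this assay compound 2 gives 0.5 nM.
Compound 3, `COc1cc(C(=O)NS(=O)(=O)c2ccccc2C)ccc1Cc1cn(C(=O)NCCCc2ccccc2)c2ccc(NC(=O)OC3CCCC3)cc12`: in this assay compound 3 gives 0.5 nM.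

Compound 3 stands level with compound 2 at the digits given, the two together holding the highest numbers of the three, while the remaining step is a 1.3-fold higher number from compound 1 to compound 3 (0.10 log units; within the scatter) and so within the scatter; there is no order to speak of among these three.

Compound 4 is `COc1cc(C(=O)NS(=O)(=O)c2ccccc2C)ccc1Cc1cn(C(=O)NCCN(C)C)c2ccc(NC(=O)OC3CCCC3)cc12`. It differs from compound 3 by dimethylamino in place of benzyl on a saturated chain carbon, two bonds along the chain from an amide-type nitrogen. Among the compounds with values here, the steps that bear on this change are those at the same carbonyl nitrogen: a 1.3-fold higher number from compound 1 to compound 2 (0.10 log units; within the scatter), a 1.3-fold higher number from compound 1 to compound 3 (0.10 log units; within the scatter) and no change at the digits printed from compound 2 to compound 3 (within the scatter). Three rather different substituents there left the number essentially where it was, so the step that is expected here is also none beyond the scatter, no change at the digits printed from compound 3 to compound 4 (within the scatter). Compound 4 is therefore estimated at 0.5 nM in this assay, with a range from 0.2 nM to 1.3 nM.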

Compound 4, half-maximal inhibitory concentration: 0.5 nM
The estimate for compound 4 equals the measured number at the digits printed, and the stated range covers the measured number.
By their numbers in this assay, from the lowest: compounds 1, 2, 3 and 4 (each within the scatter of the next).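

Dimethylamino in place of benzyl, on a saturated chain carbon, two bonds along the chain from an amide-type nitrogen, removes the side chain's aromatic ring and adds a hydrogen-bond acceptor, and this assay shows no change at the digits printed from compound 3 to compound 4 (within the scatter). Among the four compounds, only this side chain carries a second nitrogen, yet (2-(dimethylamino)ethyl)amino in place of diethylamino gives no change at the digits printed from compound 2 to compound 4 (within the scatter), and in place of dimethylamino gives a 1.3-fold higher number from compound 1 to compound 4 (0.10 log units; within the scatter). Nothing measured here accounts for this flat result.

On these data alone, it remains open whether a carboxylic acid at the end of this chain, or a longer chain ending in dimethylamino, would also stay level. The rest of the structure is the same in all four compounds, so these steps say nothing about how a change elsewhere would read.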